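From Chlorine to a Silicon-Bearing Group

The source may report more compounds than this note shows. Statements on the series, on what has been measured and on what is new or still open speak of the compounds shown alone.

In a functional assay on MCF7 cells (Homo sapiens) for antiproliferative activity, read by MTT assay, with a stated time of 48 h (on this read-out higher numbers stand for weaker inhibition and lower numbers for stronger inhibition), compound 1 (`CC(=O)OC/C1=C/C[C@](C)(CCC=C(C)C)/C=C/[C@@H](OC(=O)C=C(C)C)[C@](C)(OC(C)=O)/C=C/C1=O`) gives 3990 nM, compound 2 (`CC(=O)O[C@]1(C)/C=C/C(=O)/C(CO)=C\C[C@](C)(CCC=C(C)C)/C=C/[C@H]1OC(=O)C=C(C)C`) gives 2320 nM, and compound 3 (`CC(C)=CCC[C@]1(C)/C=C/[C@@H](OC(=O)C=C(C)C)[C@](C)(O)/C=C/C(=O)/C(CCl)=C\C1`) gives 610 nM, the lowest number of the three and beyond the scatter from both others. Compound 4 (`CC[Si](CC)(CC)C/C1=C/C[C@](C)(CCC=C(C)C)/C=C/[C@@H](OC(=O)C=C(C)C)[C@](C)(O)/C=C/C1=O`) carries this change: a group of 7 heavy atoms (6 carbon, 1 silicon; no ring) in place of one chlorine atom, on a saturated chain carbon bound to a double-bonded ring carbon. For the measured compounds named here, the only measured single-place step, a 1.7-fold lower number from compound 1 to compound 2 (0.24 log units; within the scatter), puts hydrogen in place of acetyl on an oxygen and stays within the scatter. Going by the values given here, no measured compound carries silicon, so the data offer no direct guide. Compound 3 alone carries the chlorine, and without it the number is expected to move back towards compound 2 at 2320 nM. In this assay the expected step is a 2.5-fold higher number from compound 3 to compound 4 (0.39 log units; beyond the scatter), towards weaker inhibition. For compound 4 the estimate is 1500 nM, with an expected range of 500 nM to 4500 nM.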

Compound 4, half-maximal inhibitory concentration: 3150 nM
The estimate for compound 4 lay 2.1-fold (0.32 log units) below the measured number; the measured number falls inside the stated range.
By their numbers in this assay, from the lowest: compound 3; then compounds 2, 4 and 1 (each within the scatter of the next).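

In this assay, replacing the chloro group with the silicon-bearing group gives a 5.2-fold higher number from compound 3 to compound 4 (0.71 log units; beyond the scatter), towards weaker inhibition. For the compounds shown here, this shows that the saturated chain carbon bound to a double-bonded ring carbon responds to a change of substituent by more than the usual scatter, which the one earlier step, made on an oxygen, did not show. Nothing measured here accounts for this shift. Going by these compounds alone, the single step cannot separate the loss of chlorine from the entry of the silicon-bearing group. Going by these compounds, how a bromine atom or an amine on this carbon would read remains open.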